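Aryl Variation at the Vinyl Carbon in DU-145 Growth Inhibition

This account rests on a few compounds, and the source may have more. Where it says the series, first, only, none or still open, it means among the compounds named here.

Measured compounds, in a functional assay on DU-145 cells (Homo sapiens) for inhibition, read by trypan blue exclusion, with a stated time of 96 h; on this read-out higher numbers stand for weaker inhibition of growth and lower numbers for stronger inhibition of growth:
compound 1 `Nc1c(Br)cc(Br)cc1/C=C(\C(=O)c1ccc(Br)cc1)S(=O)(=O)c1ccc(Br)cc1`, 25000 nM
compound 2 `O=C(/C(=C\c1ccc(Cl)c([N+](=O)[O-])c1)S(=O)(=O)c1ccc(Br)cc1)c1ccc(Br)cc1`, 10000 nM
compound 3 `O=C(/C(=C\c1ccc(Cl)cc1Cl)S(=O)(=O)c1ccc(Br)cc1)c1ccc(Br)cc1`, 10000 nM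

Compound 3 stands level with compound 2, the two together the lowest numbers of the three; compound 1 lies furthest away, as a 2.5-fold lower number from compound 1 to compound 3 (0.40 log units; beyond the scatter) shows. Compound 4 `O=C(/C(=C\c1ccc(Br)c(O)c1)S(=O)(=O)c1ccc(Br)cc1)c1ccc(Br)cc1` is not yet measured. It differs from compound 3 in one place: 4-bromo-3-hydroxyphenyl in place of 2,4-dichlorophenyl on a double-bonded chain carbon bound to a double-bonded chain carbon.

Bearing on this step are no change at the digits printed from compound 2 to compound 3 (within the scatter) and, at one remove, a 2.5-fold lower number from compound 1 to compound 2 (0.40 log units; beyond the scatter) and a 2.5-fold lower number from compound 1 to compound 3 (0.40 log units; beyond the scatter). Among the measured compounds shown here, the one comparison between two aryl groups lacking an amino group, compound 2 against compound 3, shows no change, so in this assay no step beyond the scatter is expected; a hydroxyl on this ring has no precedent here. Compound 4 is therefore estimated at 10000 nM, range 4000 nM to 25000 nM, the expected step being no change at the digits printed from compound 3 to compound 4 (within the scatter).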

Compound 4, concentration for 50% growth inhibition: 50000 nM
Compound 4: middle estimate off by 5.0-fold (0.70 log units), on the low side, outside the stated range (above it).
By their numbers in this assay, from the lowest: compounds 2 and 3 (each within the scatter of the next); then compounds 1 and 4 (each within the scatter of the next).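

In this assay, the aryl group on a double-bonded chain carbon bound to a double-bonded chain carbon now matters among groups lacking an amino group: 4-bromo-3-hydroxyphenyl gives a 5.0-fold higher number from compound 3 to compound 4 (0.70 log units; beyond the scatter) and a 5.0-fold higher number from compound 2 to compound 4 (0.70 log units; beyond the scatter). Compound 4 instead falls level with the amino-bearing compound 1, with a 2.0-fold higher number from compound 1 to compound 4 (0.30 log units; within the scatter). No measurement at hand bears on what lies behind these steps.

From the compounds shown here alone, whether the hydroxyl or the bromine carries the step remains open. A methoxy group in place of that hydroxyl would begin to separate the two.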